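A few compounds are considered here, and "the series" means these few. Any claim that something is new, unique, unknown or untested is made for them only; others in the source may bear on it.

Measured so far:
Compound 1 `COc1ccc(-c2nc3sc(Cc4ccccc4)nn3c2SC#N)cc1`: 60300 nM
Compound 2 `Clc1ccc(-c2cn3nc(Cc4ccccc4)sc3n2)cc1`: 12000 nM

In a functional assay on cells (Cancer cell lines, Homo sapiens) for inhibition (a higher number here means a weaker inhibitor of growth, a lower number a stronger inhibitor of growth), compound 1 gives 60300 nM, the highest of the two numbers; compound 2 gives 12000 nM, a gap beyond the scatter. Compound 3 `N#CSc1c(-c2ccccc2)nc2sc(Cc3ccccc3)nn12`, not yet measured, differs from compound 1 by hydrogen in place of methoxy on an aromatic carbon. Within the data shown here, no measured pair shows this change, so the expectation rests on compound 1 alone. The step of a 1.5-fold lower number from compound 1 to compound 3 (0.18 log units; within the scatter) is expected to be small, toward a lower number, within or just beyond the scatter. Compound 3 is estimated at 40000 nM, between 14000 nM and 120000 nM.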

Compound 3, concentration for total growth inhibition: 75900 nM
Estimate against measurement, compound 3: 1.9-fold (0.28 log units) below; the range from low to high includes it.
By their numbers in this assay, from the lowest: compound 2; then compounds 1 and 3 (each within the scatter of the next).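

Going from 4-methoxyphenyl to phenyl in this assay gives a 1.3-fold higher number from compound 1 to compound 3 (0.10 log units; within the scatter) and so this one change, on an aromatic carbon para to a large group, does not separate the two compounds. On this core, then, methoxy and hydrogen at this place cannot be told apart by growth inhibition. Nothing available explains this outcome. Going by these compounds, whether an amine, a carboxylic acid or a longer alkoxy chain at the same place would shift the number remains open. So does whether methoxy and hydrogen would also match on the core of compound 2.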